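This account rests on a few compounds, and the source may have more. Where it says the series, first, only, none or still open, it means among the compounds named here.

In a functional assay on SAOS-2 cells (Homo sapiens) for cytotoxicity, read by MTT assay, with a stated time of 24 h (on this read-out higher numbers stand for weaker inhibition and lower numbers for stronger inhibition), compound 1 `C=C1C(=O)[C@H]2C[C@@H]1CC1=C2[C@]2(C)CCC[C@](C)(CO)[C@H]2CC1` gives 35500 nM. Compound 2 `C[C@@H]1C(=O)[C@H]2C[C@]1(O)CC1=C2[C@]2(C)CCC[C@](C)(CO)[C@H]2CC1` gives only a limit of the assay in this assay, namely > 50000 nM, so no exact number is known for it. Compound 2 therefore stands at the limit of > 50000 nM in this assay, at which 1 of the 2 values shown sits. Compound 3 `C[C@@H]1C(=O)[C@H]2C[C@]1(O)CC1=C2[C@]2(C)CCCC(C)(C)[C@H]2CC1` differs from compound 2 in one place: hydrogen in place of hydroxy on a saturated chain carbon bound to a saturated ring carbon. No pair of measured compounds differing in just this way is shown, so the size of such a step cannot be read from the numbers at hand. The expectation is that the step from compound 2 to compound 3 stays within the usual scatter, a number no higher from compound 2 to compound 3 (the limit leaves the size open). Compound 3 is therefore expected to give about 50000 nM in this assay, within a range from 20000 nM to 120000 nM, and it may once more give only a limit rather than a number.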

Compound 3, half-maximal inhibitory concentration: > 50000 nM
Compound 3 gave a limit, no number (the forecaster's own chance of this, stated with the estimate: 60%); the middle value lies on the limit itself.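

In this assay compound 2 and compound 3 both give only a limit of the assay rather than a number, so no step between them can be read: the limit of > 50000 nM in this assay, at which 2 of the 3 values shown sit.

As far as these compounds go, whether hydrogen in place of hydroxy at this place changes the read-out at all, and by how much, stays open.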